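The source may report more compounds than this note shows. Statements on the series, on what has been measured and on what is new or still open speak of the compounds shown alone.

Compound 3 `CC(C)(C)CCOc1cccc2ccc(N)nc12` gives 201 nM in an assay on cells with melanin-concentrating hormone receptor 1 (Homo sapiens) as the target, read by radioligand binding (on this read-out lower numbers stand for stronger inhibition and higher numbers for weaker inhibition), the lowest of the two numbers in hand; the nearest is compound 2 `Nc1ccc2cccc(OCC3CCC3)c2n1`, which gives 432 nM. Compound 1 `CSCCOc1cccc2ccc(N)nc12` yields only a limit, > 2000 nM, as it sits at the limit of > 2000 nM in this assay, at which 1 of the 3 values shown sits. The step to compound 4 `CCCC(C)Oc1cccc2ccc(N)nc12` is 1-methylbutyl in place of 3,3-dimethylbutyl on an oxygen on an aromatic ring. Going by the values given here, no measured step alters the chain at the carbon bound to the oxygen in this way, so the bearing of the earlier steps is indirect: a 2.1-fold lower number from compound 2 to compound 3 (0.33 log units; beyond the scatter) shows that exchanging one carbon group on the same oxygen for another of similar size moves the number only modestly, while an at least 9.9-fold lower number from compound 1 to compound 3 (0.99 log units; beyond the scatter) shows a larger shift when the sulfur-containing chain is replaced. Since the chain entering compound 4 is shorter and carries no sulfur, a modest change at most is expected, with the number for compound 4 expected to lie somewhat above that of compound 3, by a 1.6-fold higher number from compound 3 to compound 4 (0.20 log units; within the scatter). Compound 4 is thus estimated at 320 nM, within a range from 130 nM to 800 nM.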

Compound 4, half-maximal inhibitory concentration: 105 nM
Beside the measured number, compound 4's estimate is 3.0-fold (0.48 log units) above it; measured number below the stated range.
By their numbers in this assay, from the lowest: compounds 4 and 3 (each within the scatter of the next); then compound 2. At a limit, above all of these: compound 1.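

With 1-methylbutyl in place of 3,3-dimethylbutyl on an oxygen on an aromatic ring, the chain drops from 6 to 5 heavy atoms, yet the result in this assay stays within the scatter (a 1.9-fold lower number from compound 3 to compound 4 (0.28 log units; within the scatter)), so this position accepts either chain without a change that can be told apart. The new chain also separates from the cyclobutylmethyl group of compound 2 (a 4.1-fold lower number from compound 2 to compound 4 (0.61 log units; beyond the scatter)) and from the sulfur-containing chain of compound 1 (an at least 19-fold lower number from compound 1 to compound 4 (1.27 log units; beyond the scatter)), the latter being the largest step shown here. Compound 1 is known only as a limit, so that step has no fixed size: the limit of > 2000 nM in this assay, at which 1 of the 4 values shown sits.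

What the compounds shown leave open is how an amine, a carboxylic acid or a hydroxyl group on this chain would fare. They also leave open whether a longer chain would keep the number as low as those of compound 3 and compound 4.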